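This account rests on a few compounds, and the source may have more. Where it says the series, first, only, none or still open, it means among the compounds named here.

Compound 3 `O=C1COc2ccc(-c3cnc(Cl)c(NS(=O)(=O)c4ccc(F)cc4)c3)cc2N1C1CCCCC1` sits at the edge of what a functional assay on HepG2 cells (Homo sapiens) for antiproliferative activity, read by MTT assay, with a stated time of 72 h (a higher number here means a weaker inhibitor, a lower number a stronger inhibitor), can report: in this assay compound 3 gives > 40000 nM, which is a limit of the assay and not a number. Compound 1 `COc1cccc(N2C(=O)COc3ccc(-c4cnc(Cl)c(NS(=O)(=O)c5ccc(F)cc5)c4)cc32)c1` likewise gives > 40000 nM, a limit. Compound 2 `O=C1COc2ccc(-c3cnc(Cl)c(NS(=O)(=O)c4ccc(F)cc4)c3)cc2N1c1ccc(F)cc1` gives > 40000 nM, also a limit. All three values rest at the limit of > 40000 nM in this assay, at which 3 of the 3 values shown sit. Compound 4 `O=C1COc2ccc(-c3cnc(Cl)c(NS(=O)(=O)c4ccc(F)cc4)c3)cc2N1c1ccc(Cl)cc1` has not yet been measured; it differs from compound 3 by 4-chlorophenyl in place of cyclohexyl on an amide-type nitrogen in a ring. The measured steps that bear on this change, a step that the two limits leave unreadable from compound 1 to compound 2, a step that the two limits leave unreadable from compound 1 to compound 3 and a step that the two limits leave unreadable from compound 2 to compound 3, all have a size that cannot be read, so no direction can be taken from them. Compound 4 is therefore expected to give about 40000 nM, between 15000 nM and 100000 nM, most probably again as a limit. This estimate means a step of a number no higher from compound 3 to compound 4 (the limit leaves the size open), none beyond the scatter.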

Compound 4, half-maximal inhibitory concentration: 33900 nM
The estimate for compound 4 lay 1.2-fold (0.07 log units) above the measured number, within the range that was stated.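

On the amide-type nitrogen, 4-chlorophenyl gives a readable number in this assay: compound 4 gives 33900 nM. Compound 1, compound 2 and compound 3 each gave only a limit. Replacing cyclohexyl gives an at least 1.1-fold lower number from compound 3 to compound 4 (0.07 log units; that floor lies within the scatter), chloro in place of fluoro gives an at least 1.1-fold lower number from compound 2 to compound 4 (0.07 log units; that floor lies within the scatter), and replacing 3-methoxyphenyl gives an at least 1.1-fold lower number from compound 1 to compound 4 (0.07 log units; that floor lies within the scatter); each is only a floor, and each floor lies within the scatter. The true sizes of these steps, like those among the first three compounds, cannot be read because most values rest at a limit: the limit of > 40000 nM in this assay, at which 3 of the 4 values shown sit.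

As far as these compounds go, it remains open whether a chain carrying an amine or a carboxylic acid on this nitrogen would give a clearly lower number. From the compounds shown here alone, it also remains open whether a methyl group there would do so.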